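This account rests on a few compounds, and the source may have more. Where it says the series, first, only, none or still open, it means among the compounds named here.

Measured so far:
- compound 1, `CC(C)(C)c1ccc(NC(=O)c2ccc(-c3ncccc3C#N)cc2)cc1`: 30 nM
- compound 2, `CCCNc1cccnc1-c1ccc(C(=O)Nc2ccc(C(C)(C)C)cc2)cc1`: 158 nM

Both compounds were tested in a functional assay for antagonist activity at transient receptor potential cation channel subfamily V member 1 (Homo sapiens), read by FLIPR; on this read-out higher numbers stand for weaker inhibition and lower numbers for stronger inhibition. Going by the values given here, compound 1 gives 30 nM and compound 2 gives 158 nM, so compound 2 has the higher of the two numbers, meaning the weaker inhibition, and the single step between them, a 5.3-fold higher number from compound 1 to compound 2 (0.72 log units; beyond the scatter), lies beyond the scatter.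

The next compound, compound 3, has the structure `CC(C)(C)c1ccc(NC(=O)c2ccc(-c3ncccc3NC3CCCC3)cc2)cc1`. It differs from compound 2 in one place: cyclopentyl in place of propyl on a nitrogen on an aromatic ring, that is, propylamino becomes cyclopentylamino.

Among the compounds with values here, no measured pair shows this kind of change. Within the data shown here, the only step on record, a 5.3-fold higher number from compound 1 to compound 2 (0.72 log units; beyond the scatter), swaps a nitrile for the propylamino group and is of modest size, but it says nothing about enlarging the chain on that nitrogen into a ring. The expectation for compound 3 therefore rests mainly on compound 2 itself, with a wide allowance in both directions; the expected step is a 1.3-fold lower number from compound 2 to compound 3 (0.12 log units; within the scatter). On that basis compound 3 is estimated to give about 120 nM in this assay, within a range from 35 nM to 450 nM.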

Compound 3, half-maximal inhibitory concentration: 190 nM
Estimate against measurement, compound 3: 1.6-fold (0.20 log units) below; the measured number falls inside the stated range.
By their numbers in this assay, from the lowest: compound 1; then compounds 2 and 3 (each within the scatter of the next).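

Replacing propyl with cyclopentyl on a nitrogen on an aromatic ring gives a 1.2-fold higher number from compound 2 to compound 3 (0.08 log units; within the scatter) in this assay, so this pair does not separate the open chain from the five-membered ring of carbon only. Compound 2 and compound 3 can therefore be read as one level on this read-out, at least for these two groups on that nitrogen. The nitrile of compound 1 stays apart from the new amine as well, with cyclopentylamino in its place giving a 6.3-fold higher number from compound 1 to compound 3 (0.80 log units; beyond the scatter), a modest step like the earlier one to propylamino, and nothing available here bears on why the two amines read alike or why both stand apart from the nitrile.

The compounds shown leave open whether any other group on that nitrogen, such as a methyl, a longer chain or a phenyl ring, would bring the number back toward that of compound 1, at 30 nM. They also leave open whether the hydrogen on that nitrogen matters, which a dimethylamino group or a methoxy group in the same place could test.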